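The source may report more compounds than this note shows. Statements on the series, on what has been measured and on what is new or still open speak of the compounds shown alone.

Measured so far in a functional assay on KB cells (Homo sapiens) for antiproliferative activity, read by sulforhodamine B assay, with a stated time of 72 h; on this read-out lower numbers stand for stronger inhibition and higher numbers for weaker inhibition:
- compound 1 `O=C(/C=C/c1csc2ccccc12)c1cc(Br)ccc1O`: 760 nM
- compound 2 `COc1ccc(O)c(C(=O)/C=C/c2csc3ccccc23)c1`: 640 nM

Among the measured compounds shown here, only two compounds have been measured, so there is little to compare. Compound 2, at 640 nM, stands level with compound 1 within the usual scatter of repeated measurements.

The next compound is compound 3 `COc1ccc(OC)c(C(=O)/C=C/c2csc3ccccc23)c1`. It keeps the core of compound 2 and carries methyl in place of hydrogen on an oxygen on an aromatic ring, so a hydroxy becomes a methoxy: methyl in place of hydrogen on an oxygen on an aromatic ring.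

For the measured compounds named here, only one measured step is available as a guide: a 1.2-fold lower number from compound 1 to compound 2 (0.07 log units; within the scatter). That step put methoxy in place of bromo on an aromatic carbon, which is a different change from the one made here, and it stayed within the scatter. Going by the values given here, no measured pair shows a hydroxy turning into a methoxy, so the data give no direction for this change. No step beyond the scatter is the plainest expectation, though with real uncertainty.

The expected change is a 1.3-fold lower number from compound 2 to compound 3 (0.11 log units; within the scatter). Compound 3 is estimated at 500 nM, with an expected range of 100 nM to 2500 nM.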

Compound 3, half-maximal inhibitory concentration: 4600 nM
Estimate against measurement, compound 3: 9.2-fold (0.96 log units) below, outside the stated range (above it).
By their numbers in this assay, from the lowest: compounds 2 and 1 (each within the scatter of the next); then compound 3.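

In this assay the hydroxy of compound 2 cannot be capped freely: there is a 7.2-fold higher number from compound 2 to compound 3 (0.86 log units; beyond the scatter) and this step, unlike a 1.2-fold lower number from compound 1 to compound 2 (0.07 log units; within the scatter) at the other substituted place on the same ring, lies beyond the scatter. A newcomer might expect so small an edit to matter little, yet only a hydrogen leaves and a single methyl enters on that oxygen, and inhibition becomes clearly weaker, so this place on the ring responds to even a one-carbon change in these compounds. The data show that the loss occurs but not what lies behind it, and no measurement available here speaks to its cause.

As far as these compounds go, it remains open whether the free hydroxy itself matters or whether the added methyl is what does the harm, and an amine or a fluorine in place of the hydroxy would help to separate those two readings. Also open, from the compounds shown here alone, is whether a longer chain on the same oxygen, such as ethoxy, would weaken inhibition further, and whether the same change would cost as much with bromo in place of the methoxy that compound 2 already carries.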